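The compounds below may be only part of what the source reports. "The series", "measured", "known", "first", "only" and "open" are said of these compounds alone.

Compound 1 `COc1cc(-n2cnc3ccc(-c4ccc(C)cc4F)cc32)cc(OC)c1OC` carries a 2-fluoro-4-methylphenyl group on the shared core. In a functional assay on A549 cells (Homo sapiens) for antiproliferative activity, read by MTT assay, with a stated time of 72 h (on this read-out higher numbers stand for weaker inhibition and lower numbers for stronger inhibition), compound 1 gives > 10000 nM, which is a limit of the assay and not a number (the limit of > 10000 nM in this assay, at which 1 of the 3 values shown sits). Compound 2 `COc1cc(-n2cnc3ccc(-c4cccc(F)c4)cc32)cc(OC)c1OC` gives 5270 nM in this assay. Compound 3 `COc1cc(-n2cnc3ccc(-c4ccc(F)cc4)cc32)cc(OC)c1OC` gives 6740 nM in this assay. Replacing the 2-fluoro-4-methylphenyl group produced an at least 1.8-fold lower number from compound 1 to compound 2 (0.27 log units; that floor lies within the scatter) and an at least 1.4-fold lower number from compound 1 to compound 3 (0.17 log units; that floor lies within the scatter), while between the two singly substituted analogues there was a 1.3-fold higher number from compound 2 to compound 3 (0.11 log units; within the scatter). Compound 4 `COc1cccc(-c2ccc3ncn(-c4cc(OC)c(OC)c(OC)c4)c3c2)c1` differs from compound 1 by 3-methoxyphenyl in place of 2-fluoro-4-methylphenyl on an aromatic carbon. Since both earlier exchanges of this group gave numbers near those of compound 2 and compound 3, compound 4 is expected to show an at least 1.6-fold lower number from compound 1 to compound 4 (0.22 log units; that floor lies within the scatter). The estimate for compound 4 in this assay is 6000 nM, expected to lie between 2500 nM and 15000 nM.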

Compound 4, half-maximal inhibitory concentration: 3180 nM
The estimate for compound 4 lay 1.9-fold (0.28 log units) above the measured number; measured number inside the range.
By their numbers in this assay, from the lowest: compounds 4, 2 and 3 (each within the scatter of the next, the first and the last beyond it). At a limit, above all of these: compound 1.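

In this assay, the exchange for 3-methoxyphenyl gives an at least 3.1-fold lower number from compound 1 to compound 4 (0.49 log units; beyond the scatter), the first step away from the 2-fluoro-4-methylphenyl group to clear the scatter, though it is only a floor set by a limit of the assay: the limit of > 10000 nM in this assay, at which 1 of the 4 values shown sits. Against the fluorophenyl analogues the result splits: there is a 2.1-fold lower number from compound 3 to compound 4 (0.33 log units; beyond the scatter), beyond the scatter, but also a 1.7-fold lower number from compound 2 to compound 4 (0.22 log units; within the scatter), within it, so methoxy and fluoro on this phenyl ring cannot be told apart here. The compounds shown leave open whether an amine or a carboxylic acid on this phenyl ring would lower the number further.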